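The compounds below may be only part of what the source reports. "The series", "measured", "known", "first", "only" and "open" are said of these compounds alone.

Among the compounds with values here, the series turns on a quinolinone-type amide core carried by compound 2 `COc1ccc([C@H](C)N(Cc2ccc(C(C)(C)C)cc2)Cc2cc3ccccc3[nH]c2=O)cc1`, which in a toxicity assay on MDCK cells (Canis lupus familiaris) for cytotoxicity, read by crystal violet staining, with a stated time of 48 h (a higher number here means that more compound is tolerated, a lower number that less compound is tolerated), gives 1800 nM, the only numeric reading in the set. Compound 1 `COc1ccc(C(C)N(Cc2ccc(C(C)(C)C)cc2)Cc2cc3cc(C4CC4)ccc3[nH]c2=O)cc1Cl` is a close relative that differs from the others in more than one place. In this assay compound 1 reaches only a limit of the assay, > 10000 nM, and that limit is the sole further entry beside the number for compound 2 (the limit of > 10000 nM in this assay, at which 1 of the 2 values shown sits). Compound 3 `COc1ccc([C@H](C)N(Cc2ccc(C(C)(C)C)cc2)Cc2cc3cc(C4CC4)ccc3[nH]c2=O)cc1` is built from compound 2 by a single change, (cyclopropyl in place of hydrogen on an aromatic carbon), in words cyclopropyl in place of hydrogen on an aromatic carbon. Within the data shown here, no measured step between two compounds is available to calibrate this change, so its likely size can only be guessed from what compound 1 and compound 2 show side by side: the compound bearing the cyclopropyl sits at the limit, the compound lacking it gives a number. On that basis a step upward, beyond the scatter, is expected in this assay from compound 2 to compound 3 , of about a 3.3-fold higher number from compound 2 to compound 3 (0.52 log units; beyond the scatter), and compound 3 is estimated at 6000 nM, within a range from 2000 nM to 20000 nM.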

Compound 3, half-maximal cytotoxic concentration: > 10000 nM
Compound 3 ended at the assay's limit; the forecaster's own chance of this, stated with the estimate: 40%; at least 1.6-fold (0.22 log units) between middle value and limit.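

With the cyclopropyl in place of hydrogen on an aromatic carbon, the earlier side-by-side reading of two compounds that differed in more than one place gives way to a change in a single place, and in this assay that change gives an at least 5.5-fold higher number from compound 2 to compound 3 (0.74 log units; beyond the scatter). Going by these compounds, the position concerned is on an aromatic carbon of a six-membered aromatic ring of carbon only, meta to a fused ring and para to a fused ring, and a cyclopropyl there raises the tolerated concentration beyond the scatter, although the true size of the step stays open-ended at the upper end. The step that swaps 1-(3-chloro-4-methoxyphenyl)ethyl for 1-(4-methoxyphenyl)ethyl on the amine nitrogen cannot be read, so the chlorine's part in this assay remains unknown, and the cyclopropyl compounds cannot be told apart: the limit of > 10000 nM in this assay, at which 2 of the 3 values shown sit.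

On these data alone, how far compound 3 lies past the limit remains open, and so does any ranking of it against compound 1. Also open, as far as these compounds go, is whether a methyl, a longer chain, an amine or a carboxylic acid on the same aromatic carbon would shift the reading in the same direction as the cyclopropyl.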